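The compounds below may be only part of what the source reports. "The series", "measured", "known", "first", "only" and "open" are said of these compounds alone.

Of the compounds shown here, three sharing one core have been measured in a physicochemical assay for solubility; a lower number here means a less soluble compound, a higher number a more soluble compound. Compound 1 `O=C(c1ccc(Cl)cc1)N1CCC(NS(=O)(=O)c2cc(S(=O)(=O)c3ccccc3)ccc2C(F)(F)F)CC1` gives 3100 nM, compound 2 `CN(C)c1ccc(C(=O)N2CCC(NS(=O)(=O)c3cc(S(=O)(=O)c4ccccc4)ccc3C(F)(F)F)CC2)cn1` gives 12500 nM, and compound 3 `O=S(=O)(NC1CCN(S(=O)(=O)c2ccccc2)CC1)c1cc(S(=O)(=O)c2ccccc2)ccc1C(F)(F)F` gives 25000 nM. Compound 3 stands well clear of compound 1, as an 8.1-fold higher number from compound 1 to compound 3 (0.91 log units; beyond the scatter) shows, while a 2.0-fold higher number from compound 2 to compound 3 (0.30 log units; within the scatter) leaves it level with compound 2.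

The next molecule is compound 4 `O=C(O)CCCC(=O)N1CCC(NS(=O)(=O)c2cc(S(=O)(=O)c3ccccc3)ccc2C(F)(F)F)CC1`. It carries (3-carboxypropyl)carbonyl in place of phenylsulfonyl on an amine nitrogen in a ring. The steps already measured at this nitrogen are the closest guide. Exchanging the whole group there gave the two steps above, and swapping only 4-chlorophenyl on the carbonyl for 6-(dimethylamino)pyridin-3-yl gave a 4.0-fold higher number from compound 1 to compound 2 (0.61 log units; beyond the scatter).

Within the data shown here, no measured compound carries the entering chain, so these steps offer a sense of scale and no direct precedent. The size of a 4.0-fold higher number from compound 1 to compound 2 (0.61 log units; beyond the scatter) suggests that a change here can shift the number modestly, and a modest upward shift seems the likeliest outcome. The estimated step in this assay is a 2.4-fold higher number from compound 3 to compound 4 (0.38 log units; beyond the scatter), an expected modest rise. For compound 4 the expected value is 60000 nM, with an estimated range from 20000 nM to 150000 nM.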

Compound 4, solubility: 50000 nM
Beside the measured number, compound 4's estimate is 1.2-fold (0.08 log units) above it; the range from low to high includes it.
By their numbers in this assay, from the lowest: compound 1; then compounds 2, 3 and 4 (each within the scatter of the next, the first and the last beyond it).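

In this assay the position on the amine nitrogen in the ring takes an open chain as readily as a ring-bearing group: (3-carboxypropyl)carbonyl and phenylsulfonyl stand level, with a 2.0-fold higher number from compound 3 to compound 4 (0.30 log units; within the scatter) as the step between them. Every earlier group at this nitrogen carried a ring, so compound 4 adds the finding that a group with no ring can reach the same level as compound 3. With the carbonyl kept in place, 3-carboxypropyl on the carbonyl carbon gives a 4.0-fold higher number from compound 2 to compound 4 (0.60 log units; beyond the scatter) when it replaces 6-(dimethylamino)pyridin-3-yl and a 16-fold higher number from compound 1 to compound 4 (1.21 log units; beyond the scatter) when it replaces 4-chlorophenyl, and this last is the largest step seen so far in this set.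

The compounds shown do not separate the carboxylic acid from the chain that carries it, and the same chain ending in an amine or a methyl ester, or a longer chain ending in the acid, would be needed to tell the two apart. No measurement of any property of these groups bears on this result.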